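The source may report more compounds than this note shows. Statements on the series, on what has been measured and on what is new or still open speak of the compounds shown alone.

Compound 1 `O=C(Nc1ncc(Cc2ccc(F)cc2)s1)C1CCCCC1` and compound 2 `COCCCNc1ncc(C(Oc2ccc3cc(Br)ccc3c2)c2ccc(Cl)cc2)s1` share a core bearing an aminothiazole-type nitrogen substituent; compound 3 `O=C(Nc1ncc(C(Oc2ccc3cc(Br)ccc3c2)c2ccc(Cl)cc2)s1)c1ccccc1` has not been measured. In an ADME assay on HepG2 2.2.15 cells (Homo sapiens) for cytotoxicity (a lower number here means that less compound is tolerated, a higher number that more compound is tolerated), compound 1 gives > 50000 nM, a limit of the assay and not a number, sitting at the limit of > 50000 nM in this assay, at which 1 of the 2 values shown sits. In this assay compound 2 is recorded as "not toxic" (no number reported), with no number given; compound 2 therefore stands with compound 1 at the tolerated end. Compound 3 differs from compound 2 by benzoyl in place of 3-methoxypropyl on a nitrogen on an aromatic ring. For the measured compounds named here, no measured step covers this change, so in this assay no shift beyond the scatter is expected in either direction. Compound 3 is estimated at 50000 nM (range 20000 nM to 120000 nM).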

Compound 3, half-maximal cytotoxic concentration: "not toxic" (no number reported)
Nothing numeric was reported for compound 3, and the estimate cannot be compared.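

In this assay compound 2 is recorded as "not toxic" (no number reported) and compound 3 as "not toxic" (no number reported), so no step can be read between them. Left open is whether benzoyl in place of 3-methoxypropyl shifts the tolerated concentration at all.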